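Trimming the aryl amide of compound 2 to a urea

The source may hold more compounds than are shown below. What is called first, only, known or untested is meant among the compounds shown, and "the series" means these compounds.

Compound 1 `CN(C)CC(=O)N1CCC(NS(=O)(=O)c2cc(S(=O)(=O)c3ccccc3)ccc2C(F)(F)F)CC1` and compound 2 `CN(C)c1ccc(C(=O)N2CCC[C@H]2C(=O)N2CCC(NS(=O)(=O)c3cc(S(=O)(=O)c4ccccc4)ccc3C(F)(F)F)CC2)cc1` share one core and differ in the group attached to it. In a functional assay on U2OS cells for antagonist activity at proto-oncogene Wnt-3 (Homo sapiens), read by a luciferase reporter, with a stated time of 18 h (a higher number here means that more compound is needed for the effect, a lower number that less compound is needed), compound 1 gives 280 nM, while compound 2 gives 830 nM, the higher of the two numbers and beyond the scatter from compound 1. Compound 3 `CN(C)C(=O)N1CCC[C@H]1C(=O)N1CCC(NS(=O)(=O)c2cc(S(=O)(=O)c3ccccc3)ccc2C(F)(F)F)CC1` keeps the rest of compound 2 but carries dimethylamino in place of 4-(dimethylamino)phenyl on a carbonyl carbon. Among the measured compounds shown here, no measured pair covers this exact change. The smaller group of compound 1, with its 280 nM, suggests that a smaller group may go with a lower number. The step of a 1.7-fold lower number from compound 2 to compound 3 (0.22 log units; within the scatter) is therefore expected to be modest, toward lower numbers. Compound 3 is expected to give about 500 nM, within 200 nM to 1500 nM.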

Compound 3, half-maximal effective concentration: 160 nM
The estimate for compound 3 lay 3.1-fold (0.49 log units) above the measured number; the measured number lies below the stated range.
By their numbers in this assay, from the lowest: compounds 3 and 1 (each within the scatter of the next); then compound 2.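

In this assay, putting dimethylamino in place of 4-(dimethylamino)phenyl on a carbonyl carbon gives a 5.2-fold lower number from compound 2 to compound 3 (0.71 log units; beyond the scatter), so the aromatic ring is not needed at this position. Exchanging (dimethylamino)methyl for 1-(dimethylcarbamoyl)pyrrolidin-2-yl on a carbonyl carbon gives a 1.8-fold lower number from compound 1 to compound 3 (0.24 log units; within the scatter), so these two groups are not told apart here. Nothing measured explains either step. The compounds shown leave open whether an unsubstituted phenyl on that carbonyl would behave like 4-(dimethylamino)phenyl or like dimethylamino. They also leave open whether a primary amine or a methoxy group could replace dimethylamino.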